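A phenyl swap on compound 3 in MCF7 cells

A few compounds are considered here, and "the series" means these few. Any claim that something is new, unique, unknown or untested is made for them only; others in the source may bear on it.

Of the compounds shown here, three have numbers so far in a functional assay on MCF7 cells (Homo sapiens) for cytotoxicity, read by CellTiter-Glo, with a stated time of 5 days (a lower number here means a stronger inhibitor, a higher number a weaker inhibitor), and they do not sit evenly. Compound 1 `CC/C(=C(/c1ccc(/C=C/C(=O)O)cc1)c1ccc2[nH]ccc2c1)c1ccccc1` gives 9 nM and compound 3 `CC/C(=C(/c1ccc(/C=C/C(=O)O)cc1)c1ccc2[nH]ncc2c1)c1ccc(Cl)cc1` gives 15 nM in this test, two values that lie within the usual scatter of each other. Compound 2 `CC/C(=C(/c1csc(/C=C/C(=O)O)c1)c1ccc2[nH]ncc2c1)c1ccccc1` gives 2900 nM in the same test. Compound 3 therefore stands close to compound 1 and far from compound 2, as a much stronger inhibitor than compound 2 by a gap well beyond the scatter.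

Compound 4 `CC/C(=C(/c1ccc(/C=C/C(=O)O)cc1)c1ccc2[nH]ncc2c1)c1ccccc1C` has not yet been measured. It departs from compound 3 by one change 2-methylphenyl in place of 4-chlorophenyl on a double-bonded chain carbon bound to a double-bonded chain carbon and a saturated chain carbon on a double-bonded chain carbon bound to a double-bonded chain carbon and a saturated chain carbon. For the measured compounds named here, no two measured compounds differ in one place only, so the data hold no direct measure of such a change. The expectation starts from compound 3 at 15 nM as its reference point. The estimated 1.3-fold lower number from compound 3 to compound 4 (0.10 log units; within the scatter) in this assay is expected to stay within the scatter, with no firm direction. Compound 2 at 2900 nM shows that large gaps do occur in this small set, so the expected range is kept wide. Compound 4 is estimated at 12 nM with an expected range from 4 nM to 40 nM in repeated measurements.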

Compound 4, half-maximal inhibitory concentration: 4 nM
Estimate against measurement, compound 4: 3.0-fold (0.48 log units) above, within the range that was stated.
By their numbers in this assay, from the lowest: compound 4; then compounds 1 and 3 (each within the scatter of the next); then compound 2.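

In this assay, for the compounds shown here, the exchange of 4-chlorophenyl for 2-methylphenyl, on a double-bonded chain carbon bound to a double-bonded chain carbon and a saturated chain carbon, gives the first direct reading of a single change in this set (a 3.8-fold lower number from compound 3 to compound 4 (0.57 log units; beyond the scatter)), a modest step that lies beyond the scatter. The position therefore responds to the exchange, even though the two groups have the same number of heavy atoms, the same six-membered aromatic ring of carbon only, and no hydrogen-bond donors or acceptors; what differs is that a chlorine leaves and a methyl enters. No supporting measurement bears on this step, so the data offer no account of why the number falls.

A single pair cannot show whether the step belongs to the loss of the chlorine, to the arrival of the methyl, or to the different placing that the two group names record. An unsubstituted phenyl, 2-chlorophenyl or 4-methylphenyl at this place on the core of compound 4 would separate these readings, and a 2-methoxyphenyl would test whether anything other than methyl is tolerated there.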